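The compounds below may be only part of what the source reports. "The series", "measured", "known", "first", "only" and "open" are said of these compounds alone.

Measured compounds:
Compound 1 `CC[C@H](C1CC1)n1c(=O)c(C)nc2c(-c3ccc(Cl)cc3Cl)ccnc21` gives 8.2 nM in a functional assay for antagonist activity at corticotropin-releasing factor receptor 1 (Rattus norvegicus); on this read-out higher numbers stand for weaker inhibition and lower numbers for stronger inhibition.
Compound 2 `CCC(C1CC1)n1c(=O)c(C)nc2c(-c3cc(Cl)c(OC(F)F)cc3C)ncnc21` gives 38 nM in this assay.

Going by the values given here, of the two numbers known, compound 1 holds the lower one, and the gap to compound 2 lies beyond the scatter. Compound 3 `CCCC(C)n1c(=O)c(C)nc2c(-c3ccc(Cl)cc3Cl)ccnc21` carries the change 1-methylbutyl in place of 1-cyclopropylpropyl on an aromatic nitrogen. Among the compounds with values here, no measured pair shows this exact change, so the step is expected to be small, at most a modest weakening a 1.8-fold higher number from compound 1 to compound 3 (0.26 log units; within the scatter), and possibly none beyond the scatter. Compound 3 is therefore estimated at 15 nM, with a range from 5 nM to 45 nM.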

Compound 3, half-maximal inhibitory concentration: 62 nM
The estimate for compound 3 lay 4.1-fold (0.62 log units) below the measured number; measured number outside the range, above it.
By their numbers in this assay, from the lowest: compound 1; then compounds 2 and 3 (each within the scatter of the next).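

At this position on the aromatic nitrogen, the group is not interchangeable: in this assay the move to 1-methylbutyl weakens inhibition (a 7.6-fold higher number from compound 1 to compound 3 (0.88 log units; beyond the scatter)), a step beyond the scatter. The change removes the three-membered ring and also shortens the group, and this single step cannot separate the two. Nothing available explains the loss. As far as these compounds go, it remains open whether a 1-cyclopropylethyl group, which keeps the ring on a shorter chain, or a longer open chain such as 1-methylpentyl would restore the inhibition seen with compound 1.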